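The compounds below may be only part of what the source reports. "The series", "measured", "known", "first", "only" and "open" are said of these compounds alone.

The core shared by the series is seen in compound 3 `COc1ccc(-c2cc3ccccc3nc2/C=C/C(=O)c2ccc([N+](=O)[O-])cc2)cc1`; in a functional assay on NCI-H460 cells (Homo sapiens) for antiproliferative activity, read by XTT assay, with a stated time of 72 h (on this read-out lower numbers stand for stronger inhibition and higher numbers for weaker inhibition), compound 3 gives 6470 nM. Compound 1 `COc1ccc(-c2cc3ccccc3nc2/C=C/C(=O)c2ccc(O)cc2)cc1` gives 6930 nM in this assay, and a 1.1-fold lower number from compound 1 to compound 3 (0.03 log units; within the scatter). For compound 2 `COc1ccc(C(=O)/C=C/c2nc3ccccc3cc2-c2ccc(OC)cc2)cc1` the result in this assay is only a limit, > 10000 nM (the limit of > 10000 nM in this assay, at which 1 of the 3 values shown sits). The steps of an at least 1.4-fold higher number from compound 1 to compound 2 (0.15 log units; that floor lies within the scatter) and an at least 1.5-fold lower number from compound 2 to compound 3 (0.18 log units; that floor lies within the scatter) therefore rest on that limit. Compound 3 thus stands together with compound 1, the limit of compound 2 beside them.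

Compound 4 `COc1ccc(-c2cc3ccccc3nc2/C=C/C(=O)c2ccccn2)cc1` differs from compound 3 by pyridin-2-yl in place of 4-nitrophenyl on a carbonyl carbon. The three measured steps all exchange hydroxy, methoxy and nitro on the aromatic ring attached to the carbonyl carbon, and each stays within the scatter or ends at a limit; none exchanges that ring itself, so they offer no direct guide to this change. Expected for compound 4 is a step in this assay of a 1.2-fold higher number from compound 3 to compound 4 (0.06 log units; within the scatter), not beyond the scatter, with a weaker number the more likely side. The estimate for compound 4 in this assay is 7500 nM, within 3000 nM to 20000 nM.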

Compound 4, half-maximal inhibitory concentration: 6260 nM
Beside the measured number, compound 4's estimate is 1.2-fold (0.08 log units) above it; measured number inside the range.
By their numbers in this assay, from the lowest: compounds 4, 3 and 1 (each within the scatter of the next). At a limit, above all of these: compound 2.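

Replacing the whole ring on the carbonyl carbon, not just its substituent, gives no step beyond the scatter in this assay (a 1.0-fold lower number from compound 3 to compound 4 (0.01 log units; within the scatter)) or against the hydroxy analogue (a 1.1-fold lower number from compound 1 to compound 4 (0.04 log units; within the scatter)). At this position, pyridin-2-yl therefore reads the same as 4-nitrophenyl and 4-hydroxyphenyl, so a benzene ring is not needed here to hold this level of the read-out. The comparison with 4-methoxyphenyl (an at least 1.5-fold lower number from compound 2 to compound 4 (0.20 log units; that floor lies within the scatter)) gives only a floor, and the value of compound 2 is a limit: the limit of > 10000 nM in this assay, at which 1 of the 4 values shown sits.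

Still open, as far as these compounds go, is whether an amine or a carboxylic acid on this ring, or a pyridin-3-yl ring in its place, would give a step beyond the scatter. From the compounds shown here alone, the actual number for compound 2 also remains unknown, so the 4-methoxyphenyl ring cannot yet be placed against the others.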